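A few compounds are considered here, and "the series" means these few. Any claim that something is new, unique, unknown or untested is made for them only; others in the source may bear on it.

Compounds measured so far:
compound 1 `Cc1ccc(S(=O)(=O)NC(C)C)cc1C#Cc1cc(Cl)ccc1OCC(=O)O`: 250 nM
compound 2 `CS(=O)(=O)c1ccc(Cl)c(C#Cc2cc(Cl)ccc2OCC(=O)O)c1`: 26 nM
compound 3 `Cc1ccc(S(=O)(=O)CC(C)C)cc1C#Cc1cc(Cl)ccc1OCC(=O)O`: 120 nM

In a functional assay on cells for antagonist activity at prostaglandin D2 receptor 2 (Homo sapiens), read by flow cytometry, with a stated time of 10 min (on this read-out lower numbers stand for stronger inhibition and higher numbers for weaker inhibition), compound 3 stands second highest of the three numbers; its nearest neighbour is compound 1 and the step of a 2.1-fold lower number from compound 1 to compound 3 (0.32 log units; beyond the scatter) lies beyond the scatter, while the gap to compound 2 is wider still. Compound 4 `Cc1ccc(S(C)(=O)=O)cc1C#Cc1cc(Cl)ccc1OCC(=O)O` differs from compound 3 by hydrogen in place of isopropyl on a saturated chain carbon bound to a sulfonyl sulfur. Going by the values given here, no measured step alters the sulfonyl substituent in this way; the step from compound 1 to compound 3 changed the same sulfonyl group and was modest, and compound 2, which carries a methylsulfonyl on a different core, gives 26 nM. A modest step toward a lower number is therefore expected, a 1.7-fold lower number from compound 3 to compound 4 (0.23 log units; within the scatter), so compound 4 is estimated at 70 nM, between 25 nM and 250 nM.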

Compound 4, half-maximal inhibitory concentration: 64 nM
Beside the measured number, compound 4's estimate is 1.1-fold (0.04 log units) above it; measured number inside the range.
By their numbers in this assay, from the lowest: compound 2; then compounds 4 and 3 (each within the scatter of the next); then compound 1.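

In this assay, replacing isobutylsulfonyl with methylsulfonyl gives a 1.9-fold lower number from compound 3 to compound 4 (0.27 log units; within the scatter) and so leaves these two sulfonyl groups unseparated on the shared core. Swapping the isopropylamino on the sulfonyl sulfur for methyl gives a 3.9-fold lower number from compound 1 to compound 4 (0.59 log units; beyond the scatter) and extends the earlier sulfonyl comparison to a step beyond the scatter. Methyl in place of chloro on an aromatic carbon gives a 2.5-fold higher number from compound 2 to compound 4 (0.39 log units; beyond the scatter) and shows for the first time that this aromatic substituent also registers in the read-out. No available evidence accounts for these steps. Going by these compounds, whether an ethyl or a primary amine on the sulfonyl sulfur would match methyl remains open.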